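Vero cytotoxicity notes: compound 1 to compound 4

The compounds below may be only part of what the source reports. "The series", "measured", "known", "first", "only" and "open" are said of these compounds alone.

Measured compounds:
compound 1 `COc1cc(/C(Cl)=C/C=C(\C#N)C(=O)c2c[nH]c3ccccc23)cc(OC)c1OC` — 35900 nM
compound 2 `COc1ccc2[nH]cc(C(=O)/C(C#N)=C/C=C(\Cl)c3ccc(OC)c(OC)c3)c2c1` — "not determined" (no result reported)
compound 3 `COc1ccc(/C(Cl)=C/C=C(\C#N)C(=O)c2c[nH]c3ccccc23)cc1OC` — "not determined" (no result reported)

For the measured compounds named here, in an ADME assay on Vero cells (Chlorocebus sabaeus) for cytotoxicity, read by sulforhodamine B assay, with a stated time of 48 h (on this read-out higher numbers stand for weaker inhibition of growth and lower numbers for stronger inhibition of growth), compound 1 gives 35900 nM, the only number in the set. Going by the values given here, for compound 2 this assay reports "not determined" (no result reported), and for compound 3 it reports "not determined" (no result reported), so no comparison among measured compounds is possible and no step size is known. Compound 4 `COc1cc(/C(Cl)=C/C=C(\C#N)C(=O)c2c(C)[nH]c3ccccc23)cc(OC)c1OC` differs from compound 1 by methyl in place of hydrogen on an aromatic carbon. Among the compounds with values here, with no measured step to lean on, the change is expected to leave total growth inhibition close to that of compound 1, with a step of a 1.1-fold lower number from compound 1 to compound 4 (0.05 log units; within the scatter) not beyond the scatter in either direction. Compound 4 is therefore estimated at 32000 nM, within 12000 nM to 85000 nM.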

Compound 4, concentration for total growth inhibition: 42600 nM
For compound 4 the middle estimate is 1.3-fold (0.12 log units) below the measured one; low and high end bracket the measured number.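

In this assay the series gains its first readable step, a 1.2-fold higher number from compound 1 to compound 4 (0.07 log units; within the scatter), for methyl in place of hydrogen on an aromatic carbon, next to the ring nitrogen and next to the ring atom that bears a large group. The change from 1H-indol-3-yl to 2-methyl-1H-indol-3-yl thus stays within the scatter on this read-out. No data bearing on a cause of this result are at hand.

Open, from the compounds shown here alone, is whether a larger group at this position, such as an ethyl chain or an amine, would also stay within the scatter.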